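Replacing the Thiophene Group of Compound 1

A few compounds are considered here, and "the series" means these few. Any claim that something is new, unique, unknown or untested is made for them only; others in the source may bear on it.

Measured compounds in a functional assay on HUVEC cells (Homo sapiens), read by BrdU incorporation, with a stated time of 72 h; a higher number here means a weaker inhibitor, a lower number a stronger inhibitor:
compound 1 `Cc1cc(C(=O)/C=C/c2cc3cccc(C)c3nc2Cl)c(C)s1`: "not determined" (no result reported)
compound 2 `Cc1ccc2cc(/C=C/C(=O)c3ccc(I)s3)c(Cl)nc2c1`: 135 nM
compound 3 `Cc1ccc2cc(/C=C/C(=O)c3ccc(Br)s3)c(Cl)nc2c1`: 83.6 nM

Compound 1 offers no starting point on the numbers, since the record for compound 1 reads "not determined" (no result reported). Any change from it therefore cannot be expressed as a step from a known value. The next compound is compound 4 `Cc1cccc2cc(/C=C/C(=O)c3ccc(Br)s3)c(Cl)nc12`, which keeps the core of compound 1 and carries 5-bromothiophen-2-yl in place of 2,5-dimethylthiophen-3-yl on a carbonyl carbon. The incoming group is also found in compound 3, although the core of compound 3 is not identical to that of compound 4.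

Going by the values given here, only one measured step is available: a 1.6-fold lower number from compound 2 to compound 3 (0.21 log units; within the scatter), with bromo in place of iodo on an aromatic carbon. It stays within the scatter, but it does not test the exchange made here or the difference between the two cores. No size or direction of change from compound 1 can therefore be expected in this assay. The expectation instead leans on compound 3 at 83.6 nM, with a wide margin for the untested core. For compound 4 the estimated value is 100 nM, with an expected range of 30 nM to 330 nM.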

Compound 4, half-maximal inhibitory concentration: 243 nM
Beside the measured number, compound 4's estimate is 2.4-fold (0.39 log units) below it, and the stated range covers the measured number.
By their numbers in this assay, from the lowest: compounds 3, 2 and 4 (each within the scatter of the next, the first and the last beyond it).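

No new step can be read in this assay for compound 1 and compound 4; compound 1 gives "not determined" (no result reported) and so supplies no number to compare. The compounds shown leave open what exchanging 2,5-dimethylthiophen-3-yl for 5-bromothiophen-2-yl does to this number, and how much the core difference between compound 3 and compound 4 matters. No evidence bears on the result for compound 4.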